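Benzylamino for benzyloxy on a series at its limit

The source may hold more compounds than are shown below. What is called first, only, known or untested is meant among the compounds shown, and "the series" means these compounds.

In an ADME assay on BCBL1 cells (Homo sapiens) for cytotoxicity, with a stated time of 7 days (a higher number here means that more compound is tolerated, a lower number that less compound is tolerated), compound 1 (`CN(C)c1nc(N)nc2c1ncn2/C=C1/CC1(CO)CO`) gives > 20000 nM, which is a limit and not a number. Compound 2 (`Nc1nc(OCc2ccccc2)c2ncn(/C=C3/CC3(CO)CO)c2n1`) gives > 20000 nM, also a limit. Compound 2 therefore has no exact value and stands at the limit of > 20000 nM in this assay, at which 2 of the 2 values shown sit. The next structure is compound 3 (`Nc1nc(NCc2ccccc2)c2ncn(/C=C3/CC3(CO)CO)c2n1`), with benzylamino in place of benzyloxy on an aromatic carbon. Going by the values given here, the only measured step that bears on this change is a step that the two limits leave unreadable from compound 1 to compound 2, and it offers no size to carry over. What remains is that compound 2 at > 20000 nM gives no sign of cytotoxicity to shift. The expected result, estimated as a number no higher from compound 2 to compound 3 (the limit leaves the size open), is no step beyond the scatter in this assay. Compound 3 is estimated at 20000 nM, with an expected range of 9000 nM to 40000 nM.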

Compound 3, half-maximal cytotoxic concentration: 19900 nM
Estimate against measurement, compound 3: 1.0-fold (0.00 log units) above, within the range that was stated.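

In this assay, going by these compounds alone, compound 3 gives 19900 nM, the first exact value, so with benzylamino on this aromatic carbon, next to the ring nitrogen, cytotoxicity comes within the readable range. Compound 2 gives > 20000 nM, which is a limit and not a number. Benzylamino in place of benzyloxy gives a number no higher from compound 2 to compound 3 (the limit leaves the size open), and benzylamino in place of dimethylamino gives a number no higher from compound 1 to compound 3 (the limit leaves the size open). Neither step can be read in size, so the exchange of benzyloxy for benzylamino, which adds a hydrogen-bond donor, has no measurable size. The series still sits largely at its limit: the limit of > 20000 nM in this assay, at which 2 of the 3 values shown sit.

On these data alone, whether benzylamino differs at all from benzyloxy or dimethylamino in this assay remains open. Also open, as far as these compounds go, is how this position reads with a longer chain such as phenethylamino, or with a small amine such as cyclopropylamino.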